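Ester variant of the thiophene dihydropyrimidinone series

The source may hold more compounds than are shown below. What is called first, only, known or untested is meant among the compounds shown, and "the series" means these compounds.

Of the compounds shown here, two have been measured in an assay on membranes from HEK293 cells for displacement of a labelled ligand from adenosine receptor A2b (Homo sapiens), read by scintillation counting, with a stated time of 30 min, tested at 1 uM; on this read-out lower numbers stand for less inhibition and higher numbers for more inhibition at the one concentration tested (going by the name of the read-out). Among the compounds with values here, compound 1 `CCCC(=O)C1=C(C)NC(=O)NC1c1cccs1` gives 9%, and compound 2 `CCN(CC)C(=O)C1=C(C)NC(=O)NC1c1cccs1` gives 22%; the step of a number 13 percentage points higher from compound 1 to compound 2 (beyond the scatter) places compound 2 at the top of the two numbers so far. Compound 3 `CC1=C(C(=O)OC2CCCCC2)C(c2cccs2)NC(=O)N1` is next, differing from compound 2 in one place: cyclohexyloxy in place of diethylamino on a carbonyl carbon. Within the data shown here, no measured step exchanges an amide nitrogen substituent for an alkoxy group on this carbonyl carbon, so the only bearing comes from compound 1 to compound 2, where a change at the same carbonyl carbon moved the read-out modestly. Among the measured compounds shown here, with that as the sole guide, compound 3 is expected to land near compound 2, with a step of a number 4 percentage points lower from compound 2 to compound 3 (within the scatter) that may fall within the scatter in either direction. The estimate for compound 3 is 18%, with a range from 2% to 38%.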

Compound 3, a percentage reported as inhibition, at one concentration (the size of the read-out at that concentration, not a potency): 3%
Estimate against measurement, compound 3: 15 percentage points above; the range from low to high includes it.
By their numbers in this assay, from the lowest: compounds 3 and 1 (each within the scatter of the next); then compound 2.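

Three groups have now been read on this carbonyl carbon in this assay, and diethylamino alone stands apart from the others: cyclohexyloxy in its place gives a number 19 percentage points lower from compound 2 to compound 3 (beyond the scatter) at this position. Cyclohexyloxy in place of propyl gives a number 6 percentage points lower from compound 1 to compound 3 (within the scatter), so on this read-out the six-membered ring and the hydrogen-bond acceptor that enter with cyclohexyloxy do not separate the ester from the propyl compound. Nothing at hand explains why the read-out differs between diethylamino and the other two groups.

Still open, as far as these compounds go, is whether the higher number belongs to amides at this carbonyl carbon in general or to diethylamino in particular, which a piperidine amide or a dimethylamino group could help to settle. An ethoxy ester would likewise show whether the size of the alkoxy group matters here, and all these readings remain single-concentration numbers rather than potencies.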